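Shortening a Long Chain on a Quinone Core

This account rests on a few compounds, and the source may have more. Where it says the series, first, only, none or still open, it means among the compounds named here.

Of the compounds shown here, three have been measured in an assay on isolated protein for inhibition of Polyunsaturated fatty acid 5-lipoxygenase (Homo sapiens), read by ELISA, with a stated time of 10 min; on this read-out higher numbers stand for weaker inhibition and lower numbers for stronger inhibition. Compound 1, `COC1=CC(=O)C=C(Br)C1=O`, carries a bromine on its ring and gives 1670 nM. Compound 2, `COc1cc(O)cc(Br)c1O`, is the related phenol and gives 1140 nM. Compound 3, `CCCCCCCCCCCCCC1=CC(=O)C=C(OC)C1=O`, bears a long saturated chain on the shared core and gives 1050 nM. All three numbers lie within the usual scatter of one another, so compound 3 cannot be set apart from compound 1 or compound 2 on these data; it simply sits in the same band.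

Compound 4, `CCCCCCCCCCCC1=CC(=O)C=C(OC)C1=O`, has not yet been measured. It differs from compound 3 by hydrogen in place of ethyl on a saturated chain carbon, ten or more bonds along the chain from a double-bonded ring carbon. Among the measured compounds shown here, no pair of measured compounds shows what such a trimming of the chain does here, so the expectation rests on the chain being far from the ring and the change being small relative to the whole molecule.

The step from compound 3 to compound 4 is expected to be small, a 1.2-fold higher number from compound 3 to compound 4 (0.09 log units; within the scatter), and not clearly beyond the scatter in either direction. Because compound 3 gives 1050 nM, compound 4 is estimated at 1300 nM, with a range from 600 nM to 3000 nM.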

Compound 4, half-maximal inhibitory concentration: 340 nM
For compound 4 the middle estimate is 3.8-fold (0.58 log units) above the measured one, and the stated range ends above it.
By their numbers in this assay, from the lowest: compound 4; then compounds 3, 2 and 1 (each within the scatter of the next).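

In this assay, a change that touches only the chain proves able to move the number: hydrogen in place of ethyl on a saturated chain carbon, ten or more bonds along the chain from a double-bonded ring carbon, gives a 3.1-fold lower number from compound 3 to compound 4 (0.49 log units; beyond the scatter) and so lies beyond the usual scatter, though the step is modest. The earlier compounds shown here could not show this, since no two of them differed in one place, and the three of them sat within the scatter of one another. This position therefore matters to the read-out even though the group that leaves is made of two carbons alone, with no ring, no charge and no hydrogen-bond donors or acceptors. Nothing measured here accounts for the step, so its cause remains unknown.

As far as these compounds go, a single pair gives a direction for one change and not a trend, so it remains open whether a still shorter chain would continue the step or reverse it. From the compounds shown here alone, it is equally open how a carboxylic acid or an amine in place of the ethyl would compare with the plain chains.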